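The compounds below may be only part of what the source reports. "The series", "measured", "known", "first", "only" and "open" are said of these compounds alone.

Compound 1 `CCC(C)N(C(=O)NS(=O)(=O)Oc1c(C(C)C)cccc1C(C)C)C(C)CC` is the stronger of the two measured compounds: in an assay on liver for inhibition of sterol O-acyltransferase 1 (Rattus norvegicus), using microsomes (a higher number here means a weaker inhibitor, a lower number a stronger inhibitor), compound 1 gives 12000 nM. Compound 2 `CC(C)c1cccc(C(C)C)c1OS(=O)(=O)NC(=O)Oc1ccc(F)cc1` reaches only the assay's limit, since in this assay compound 2 gives > 50000 nM, which is a limit and not a number. The step of an at least 4.1-fold higher number from compound 1 to compound 2 (0.61 log units; beyond the scatter) is therefore known only as a lower bound, as the limit of > 50000 nM in this assay, at which 1 of the 2 values shown sits, shows.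

Compound 3 `CC(C)c1cccc(C(C)C)c1OS(=O)(=O)NC(=O)Oc1c(F)cccc1F` differs from compound 2 by 2,6-difluorophenyl in place of 4-fluorophenyl on an oxygen next to a carbonyl group. Among the compounds with values here, no measured step follows this kind of change, so the only guide is that the shared core with a phenoxy group on the carbonyl already stands at the limit in compound 2. Compound 3 is therefore expected to stay near that limit, with a step that the limit leaves unreadable from compound 2 to compound 3 of essentially nothing beyond the scatter. Compound 3 is estimated at 60000 nM, within a range from 15000 nM to 250000 nM.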

Compound 3, half-maximal inhibitory concentration: 65000 nM
For compound 3 the middle estimate is 1.1-fold (0.03 log units) below the measured one; the measured number falls inside the stated range.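

In this assay compound 3 gives 65000 nM, so a phenoxy group on the carbonyl now has a real number. The change of the group on the carbonyl carbon gives a 5.4-fold higher number from compound 1 to compound 3 (0.73 log units; beyond the scatter), a step of measured size, whereas the earlier change to 4-fluorophenoxy gave only a lower bound. Compound 2 gives > 50000 nM, which is a limit and not a number, so the change from 4-fluorophenyl to 2,6-difluorophenyl cannot be read: the limit of > 50000 nM in this assay, at which 1 of the 3 values shown sits.

The compounds shown leave open how a smaller amine such as diethylamino, or a plain phenoxy group without fluorine, would compare on the same carbonyl. They also leave open whether the number of fluorine atoms on the phenyl group changes the result in this assay.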